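The source may report more compounds than this note shows. Statements on the series, on what has been measured and on what is new or still open speak of the compounds shown alone.

In an ADME assay on BJ cells (Homo sapiens), read by MTT assay, with a stated time of 72 h (on this read-out higher numbers stand for weaker inhibition and lower numbers for stronger inhibition), compound 1 `COc1nc(N)nc2c1c(-c1ccco1)cn2[C@@H]1O[C@H](CO)[C@@H](O)[C@H]1O` gives only > 100000 nM, which is a limit and not a number. The series thus meets (the limit of > 100000 nM in this assay, at which 1 of the 2 values shown sits). For the measured compounds named here, compound 2 `COc1nc(N)nc2c1c(-c1cccs1)cn2[C@@H]1O[C@H](CO)[C@@H](O)[C@H]1O` gives 99900 nM, the only actual number so far, so it has no measured neighbour to be ranked against.

Compound 3 `COc1nc(N)nc2c1c(-c1ccsc1)cn2[C@@H]1O[C@H](CO)[C@@H](O)[C@H]1O` is reached from compound 2 by moving the attachment point on the thiophene, thiophen-3-yl in place of thiophen-2-yl on an aromatic carbon. The two have the same atoms, joined differently.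

Going by the values given here, one measured step bears on this, the furan-2-yl to thiophen-2-yl exchange at the same place, a number no higher from compound 1 to compound 2 (the limit leaves the size open). Its size cannot be read, so it offers no measured scale for a change of this group, only the sign that both compounds lie in the same high region of this assay. No step beyond the scatter is therefore expected, and no direction is favoured; the expected step is a 1.1-fold lower number from compound 2 to compound 3 (0.05 log units; within the scatter). A report as a limit alone would not be surprising.

For compound 3 the estimated value is 90000 nM, with an expected range of 35000 nM to 200000 nM.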

Compound 3, half-maximal inhibitory concentration: > 100000 nM
Compound 3 ended at the assay's limit; the forecaster's own chance of this, stated with the estimate: 45%; at least 1.1-fold (0.04 log units) between middle value and limit.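

Moving the attachment point on the thiophene gives a number no lower from compound 2 to compound 3 (the limit leaves the size open). It produces no further number in this assay: compound 3, with thiophen-3-yl, ends at the limit, as compound 1 with furan-2-yl does. The furan-2-yl, thiophen-2-yl and thiophen-3-yl groups therefore all leave the series in the same high region of the read-out, and neither the attachment point nor the ring exchange has brought a clearly lower number. The steps to compound 3 from compound 2 and from compound 1 cannot be read, so neither change has a measured size, and the series now sits largely at one edge of the read-out: the limit of > 100000 nM in this assay, at which 2 of the 3 values shown sit.

For the compounds shown here, compound 2 at 99900 nM remains the only actual number, and how far compound 1 and compound 3 lie from it stays unknown. Also open, from the compounds shown here alone, is whether a different kind of group on this aromatic carbon, such as a phenyl ring, an aminomethyl group or a carboxylic acid, would give a number clearly lower than those of these five-membered aromatic rings.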